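The source may report more compounds than this note shows. Statements on the series, on what has been measured and on what is new or still open speak of the compounds shown alone.

Compound 3, `CCCc1ccc(OCC(=O)N(CC)Cc2cccs2)cc1`, carries a propyl group on its aromatic ring, and in an assay on HEK293 cells for agonist activity at transient receptor potential cation channel subfamily M member 8 (Homo sapiens), read by fluorescence and calcium flux, with a stated time of 15 min (on this read-out lower numbers stand for an effect already at smaller amounts and higher numbers for an effect only at larger amounts of compound), compound 3 gives 1810 nM. Of the two compounds in this set with a reported number, compound 3 stands at the higher one. Compound 2, `Cc1ccc(OCC(=O)N(Cc2cccs2)c2ccon2)cc1`, gives 2 nM in this assay, a gap that lies well beyond the scatter of the measurement, though compound 2 differs from compound 3 in more than one place, so the two values can only be compared as they stand. Compound 1, `CCN(Cc1cccs1)C(=O)COc1ccc(C(=O)O)cc1`, is reported in this assay as "not active" (no number reported), with no number attached.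

Compound 4, `CCN(Cc1cccs1)C(=O)COc1ccc(C)cc1`, has not yet been measured. It arises from compound 3 by a single change: hydrogen in place of ethyl on a saturated chain carbon bound to an aromatic carbon. Read one bond further out, the same difference is propyl to methyl. Among the compounds with values here, no measured pair in this set shows this exact change on its own, so its effect in this assay is not known from the data.

Compound 4 is nevertheless expected to give a lower number than compound 3, a step of a 3.6-fold lower number from compound 3 to compound 4 (0.56 log units; beyond the scatter), larger than the usual scatter but with wide uncertainty. The estimate for compound 4 in this assay is 500 nM, within a range from 50 nM to 5000 nM.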

Compound 4, half-maximal effective concentration: 8 nM
Beside the measured number, compound 4's estimate is 63-fold (1.80 log units) above it; measured number below the stated range.
By their numbers in this assay, from the lowest: compound 2; then compound 4; then compound 3.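

Cutting propyl back to methyl gives a 230-fold lower number from compound 3 to compound 4 (2.35 log units; beyond the scatter) in this assay, and this is the first reading in the set of a single change at this place, so it shows that the number responds very strongly to the ethyl that leaves the saturated chain. Compound 4 also gives a second single-change reading, at a different place: ethyl in place of 1,2-oxazol-3-yl on the amide-type nitrogen is a 4.0-fold higher number from compound 2 to compound 4 (0.60 log units; beyond the scatter), a modest step beside the large one, which shows that with methyl on the aromatic ring a compound with the simple ethyl on that nitrogen keeps a low number. Nothing in the available data explains why either change has the size it has.

Going by these compounds, with only methyl and propyl to compare at this place, it remains open whether the number climbs gradually with chain length or jumps at one point, and an ethyl group or a longer chain such as butyl would help to settle that. On these data alone, it is also open how an amine on the aromatic ring, or a methyl or a propyl group on the amide-type nitrogen, would fare.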